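The source may hold more compounds than are shown below. What is called first, only, known or untested is meant among the compounds shown, and "the series" means these compounds.

Compound 1 `C=C(C)[C@@H]1CC=C(C)/C(=N/NC(=O)Nc2nnc(-c3ccc([N+](=O)[O-])cc3)o2)C1` and compound 2 `C=C(C)[C@@H]1CC=C(C)/C(=N/NC(=O)Nc2nnc(-c3ccc(F)cc3)o2)C1` share one core and differ only in the change described as fluoro in place of nitro on an aromatic carbon. Compound 3 `CC(C)=CC/C=C(/C)C/C=N/NC(=O)Nc1nnc(-c2ccc([N+](=O)[O-])cc2)o1` carries the 4-nitrophenyl group of compound 1 on a different core, and compound 4 `CC(C)=CC/C=C(/C)C/C=N/NC(=O)Nc1nnc(-c2ccc(F)cc2)o1` is the counterpart of compound 3 with the change (fluoro in place of nitro on an aromatic carbon). How the core of compound 3 differs from the core of compound 1 is not broken down here.

In a functional assay on the whole organism (strain Swiss albino) with Mus musculus as the target, with a stated time of 4 h (on this read-out lower numbers stand for an effect already at smaller amounts and higher numbers for an effect only at larger amounts of compound), compound 1 gives 300 mg/kg. In this assay compound 2 gives 300 mg/kg, so that the step of no change at the digits printed from compound 1 to compound 2 (within the scatter) shows no effect of exchanging the nitro group for fluorine on this core. In this assay compound 3 gives 300 mg/kg, a value level with those of compound 1 and compound 2.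

The change from compound 3 to compound 4 is the same change as from compound 1 to compound 2, at the same place: on an aromatic carbon of a six-membered aromatic ring of carbon only, para to a large group. The step from compound 3 to compound 4 is therefore expected to be no change at the digits printed from compound 3 to compound 4 (within the scatter), resting on the earlier step of no change at the digits printed from compound 1 to compound 2 (within the scatter) on the other core, which did not move the read-out. Going by the values given here, because the only measured instance of this change, no change at the digits printed from compound 1 to compound 2 (within the scatter), lies within the scatter, compound 4 is estimated to come out at 300 mg/kg. The range for compound 4 is expected to run from 150 mg/kg to 600 mg/kg.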

Compound 4, minimum effective dose: 300 mg/kg
Compound 4: middle estimate and measured number agree at the digits printed, and the stated range covers the measured number.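

On the core of compound 3, the exchange of nitro for fluoro on the aromatic carbon gives no change at the digits printed from compound 3 to compound 4 (within the scatter) in this assay, and set beside the earlier step on the core of compound 1, the two results agree: the same change on two cores in this assay, no change at the digits printed (within the scatter) from compound 1 to compound 2 and no change at the digits printed (within the scatter) from compound 3 to compound 4, 1.0-fold (0.00 log units) apart, within the scatter of two such steps

Within these four compounds, then, the exchange of 4-nitrophenyl for 4-fluorophenyl carries from one core to the other as a step that leaves the minimum effective dose unmoved, and the result on the first core was a fair guide to the result on the second. This does not show that steps in general transfer between these cores, since a change that does nothing on both says little about whether a change of measurable size would carry over in the same way, and two cores are too few to support a rule for the whole series.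

The compounds shown leave open whether any other group in that place on the aromatic ring, such as an amine, a carboxylic acid or a methoxy group, would move the read-out at all. They also leave open whether such a group would then behave alike on both cores, which is the test that would give the question of transfer a real answer.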